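The source may report more compounds than this note shows. Statements on the series, on what has been measured and on what is new or still open speak of the compounds shown alone.

Measured in a functional assay on B16 cells (Mus musculus) for inhibition; a higher number here means a weaker inhibitor, a lower number a stronger inhibitor:
Compound 1 `COc1cc(/C=C/C(=O)c2cccc(NC(=O)c3ccc(Cl)c(Cl)c3)c2)ccc1O`: 3.88 ug/mL
Compound 2 `COc1cc(/C=C/C(=O)c2cccc(NC(=O)c3ccco3)c2)ccc1O`: 5.46 ug/mL
Compound 3 `COC(=O)C(=O)Nc1cccc(C(=O)/C=C/c2ccc(O)c(OC)c2)c1`: 4.41 ug/mL

The three measured compounds share one core and differ only in the group carried by the amide carbonyl carbon. Compound 2 stands at the highest of the three numbers in this assay, but its distances to the other two are small: a 1.2-fold lower number from compound 2 to compound 3 (0.09 log units; within the scatter) and, seen from the other side, a 1.4-fold higher number from compound 1 to compound 2 (0.15 log units; within the scatter). Neither separates compound 2 from its neighbours, so no order among the three can be read from these values.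

Compound 4 `CCCC(=O)Nc1cccc(C(=O)/C=C/c2ccc(O)c(OC)c2)c1` is the next member of the series. It differs from compound 2 in one place:

propyl in place of furan-2-yl on a carbonyl carbon

Every measured step bears on this change, since each of them also swaps the group on the same carbonyl carbon: a 1.4-fold higher number from compound 1 to compound 2 (0.15 log units; within the scatter), a 1.1-fold higher number from compound 1 to compound 3 (0.06 log units; within the scatter) and a 1.2-fold lower number from compound 2 to compound 3 (0.09 log units; within the scatter). All three stayed within the scatter, whether an aromatic ring or a methoxycarbonyl took that position. The step to propyl is therefore expected to produce no shift beyond the scatter in this assay, in either direction. Compound 4 is estimated at 5 ug/mL, within 2.5 ug/mL to 10 ug/mL, which means an expected step of a 1.1-fold lower number from compound 2 to compound 4 (0.04 log units; within the scatter).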

Compound 4, half-maximal inhibitory concentration: 1.43 ug/mL
Estimate against measurement, compound 4: 3.5-fold (0.54 log units) above; measured number outside the range, below it.
By their numbers in this assay, from the lowest: compound 4; then compounds 1, 3 and 2 (each within the scatter of the next).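

In this assay the group on the carbonyl carbon next to the amide-type nitrogen proves able to move the number, since propyl gives a 3.8-fold lower number from compound 2 to compound 4 (0.58 log units; beyond the scatter) and a 3.1-fold lower number from compound 3 to compound 4 (0.49 log units; beyond the scatter) as well as a 2.7-fold lower number from compound 1 to compound 4 (0.43 log units; beyond the scatter) in the three steps that end at the one compound separated from all the others, making compound 4 the strongest inhibitor of the four shown. Furan-2-yl, 3,4-dichlorophenyl and methoxycarbonyl had stayed within the scatter of one another, so the position is not indifferent to every change, and the absence of a ring does not by itself go with the lower number, as compound 3 also has no ring in that group and yet stays with compounds 1 and 2. Nothing shown here gives a measured reason for the gain seen with propyl.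

Among the compounds shown here, with only one simple alkyl group in the set, it stays open whether the lower number belongs to propyl alone or extends to a methyl, an isopropyl or a longer chain such as butyl or hexyl. As far as these compounds go, it is equally open whether such a chain would keep that number when it ends in an amine or a carboxylic acid.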